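This account rests on a few compounds, and the source may have more. Where it says the series, first, only, none or still open, it means among the compounds named here.

Compound 1 `C=CC[C@H]1C[C@]2([C@@H](C)Cc3ccc(OC)c(OC)c3)OCOC2=CC1=O` and compound 2 `C=CC[C@H]1C[C@]2([C@@H](C)Cc3ccc(OC)c(C)c3)OCOC2=CC1=O` share one core and differ only in a single substituent on the aromatic ring. Within the data shown here, in a functional assay on M14 cells (Homo sapiens) for antiproliferative activity, with a stated time of 72 h (on this read-out higher numbers stand for weaker inhibition and lower numbers for stronger inhibition), compound 1 gives 110 nM, while compound 2 gives 410 nM, the higher of the two measured numbers, with compound 1 as its only measured neighbour. Among the measured compounds shown here, the sole step measured so far is a 3.7-fold higher number from compound 1 to compound 2 (0.57 log units; beyond the scatter). Compound 3 `C=CC[C@H]1C[C@]2([C@@H](C)Cc3ccc(OC)c(C(N)=O)c3)OCOC2=CC1=O` differs from compound 2 by carbamoyl in place of methyl on an aromatic carbon. For the measured compounds named here, no measured step exchanges a methyl for a carbamoyl, so the only guide is that the one exchange already made on this aromatic carbon shifted the number beyond the scatter, and the carbamoyl is a third, unrelated group at the same place. Compound 3 is therefore expected to land in the neighbourhood of the two measured values, with the expected step of a 1.2-fold lower number from compound 2 to compound 3 (0.07 log units; within the scatter) uncertain in direction. Compound 3 is estimated at 350 nM, with a range from 90 nM to 1400 nM.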

Compound 3, half-maximal inhibitory concentration: 12 nM
Beside the measured number, compound 3's estimate is 29-fold (1.46 log units) above it, outside the stated range (below it).
By their numbers in this assay, from the lowest: compound 3; then compound 1; then compound 2.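

In this assay this aromatic carbon proves able to move the number much further than the earlier exchange showed, and downward: carbamoyl in place of methyl gives a 34-fold lower number from compound 2 to compound 3 (1.53 log units; beyond the scatter) and is a large step, while carbamoyl in place of methoxy gives a 9.2-fold lower number from compound 1 to compound 3 (0.96 log units; beyond the scatter) and is a modest one. Among these compounds, the only earlier step, a 3.7-fold higher number from compound 1 to compound 2 (0.57 log units; beyond the scatter) for methyl in place of methoxy, ran upward, so the number at this place now spans both directions, with carbamoyl giving the lowest of the three. Nothing available here accounts for the size of the carbamoyl step.

The compounds shown leave open whether a nitrile, a carboxylic acid or a carbamoyl carrying a methyl on its nitrogen would give a similarly low number at this place. They also leave open whether the carbamoyl step would hold on a core with a different chain in place of the allyl group.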